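The compounds below may be only part of what the source reports. "The series", "measured", "known", "first", "only" and "open" are said of these compounds alone.

Compound 2 `C=CCc1cc(C(C)=O)c(O)cc1OCCCCCC#N` stands lowest of the two numbers measured in an assay on isolated protein for binding affinity to leukotriene B4 receptor 1 (Homo sapiens), tested at 1 uM (on this read-out lower numbers stand for less inhibition and higher numbers for more inhibition at the one concentration tested (going by the name of the read-out)), where compound 2 gives 41%; its nearest neighbour, compound 1 `CSCc1cc(C(C)=O)c(O)cc1OCCCCCCC#N`, gives 64% in this assay, a number beyond the scatter above it. From compound 2 the study moves to compound 3 `C=CCCCCOc1cc(O)c(C(C)=O)cc1CC=C`, which is not yet measured and differs by vinyl in place of cyanomethyl on a saturated chain carbon, four bonds along the chain from an oxygen on an aromatic ring. Going by the values given here, no measured pair shows this change, so the step is expected to be small, if anything a modest fall, as a number 6 percentage points lower from compound 2 to compound 3 (within the scatter). In this assay compound 3 is estimated to give 35%, likely between 15% and 60%.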

Compound 3, a percentage reported as inhibition, at one concentration (the size of the read-out at that concentration, not a potency): 27%
Beside the measured number, compound 3's estimate is 8 percentage points above it; measured number inside the range.
By their numbers in this assay, from the lowest: compound 3; then compound 2; then compound 1.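

In this assay, vinyl in place of cyanomethyl on a saturated chain carbon, four bonds along the chain from an oxygen on an aromatic ring, gives a number 14 percentage points lower from compound 2 to compound 3 (beyond the scatter) and places compound 3 lowest of the series. Going by these compounds alone, this is the first reading of this change, and it shows that, at this position, the two groups are not interchangeable: the cyanomethyl end goes with more inhibition. Nothing measured here bears on why. Going by these compounds, whether an amine or a carboxylic acid at this chain end would give more inhibition remains open. So does the effect of a longer chain ending in vinyl.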